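A few compounds are considered here, and "the series" means these few. Any claim that something is new, unique, unknown or untested is made for them only; others in the source may bear on it.

Measured in a functional assay on A-375 cells (Homo sapiens) for antiproliferative activity; a higher number here means a weaker inhibitor, a lower number a stronger inhibitor:
- Compound 1 `O=C(Nc1ccc(-c2cscn2)cc1)C1CCN(Cc2ccc(F)c(F)c2)CC1`: a limit, > 20000 nM
- Compound 2 `O=C(Nc1ccc2scnc2c1)C1CCCN(Cc2ccc(F)c(F)c2)C1`: a limit, > 20000 nM
- Compound 3 `O=C(Nc1ccc(-c2cscn2)cc1)C1CCCN(Cc2ccc(F)cc2)C1`: 2250 nM

Among the measured compounds shown here, compound 3 gives the only number in the set, 2250 nM. The other two values are not numbers but limits: the limit of > 20000 nM in this assay, at which 2 of the 3 values shown sit.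

Compound 4 `O=C(Nc1ccc(-c2cscn2)cc1)C1CCCN(Cc2cccnc2)C1` carries pyridin-3-yl in place of 4-fluorophenyl on a saturated chain carbon bound to an amine nitrogen in a ring.

For the measured compounds named here, no measured step covers this change, so the expectation is tentative. In this assay, a shift toward weaker inhibition, beyond the scatter, is expected. The estimated change is a 2.7-fold higher number from compound 3 to compound 4 (0.43 log units; beyond the scatter).

For compound 4, the estimated value is 6000 nM, with an expected range of 2000 nM to 20000 nM.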

Compound 4, half-maximal inhibitory concentration: > 20000 nM
Compound 4 gave a limit, no number; the forecaster's own chance of this, stated with the estimate: 30%; middle value at least 3.3-fold (0.52 log units) from the limit.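

In this assay, the place on a saturated chain carbon bound to an amine nitrogen in a ring now has its first step: pyridin-3-yl in place of 4-fluorophenyl gives an at least 8.8-fold higher number from compound 3 to compound 4 (0.94 log units; beyond the scatter). A single change at this place is thus enough to take the series from a measurable value to a limit. The value of compound 4 is a limit, as are those of compound 1 and compound 2: the limit of > 20000 nM in this assay, at which 3 of the 4 values shown sit.

As far as these compounds go, the full size of the step stays open. Also open, from the compounds shown here alone, is whether the ring nitrogen or the lost fluorine accounts for it, a question that an unsubstituted phenyl at this place would address.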